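Hydroxy for Chloro on the Anilino Ring

A few compounds are considered here, and "the series" means these few. Any claim that something is new, unique, unknown or untested is made for them only; others in the source may bear on it.

Compound 1 `N#Cc1c(Cl)nc(SCC(=O)Nn2c(COc3ccc(Cl)cc3Cl)nc3ccccc3c2=O)nc1-c1ccccc1` gives 66.7% in a functional assay on the whole organism (strain albino) for inhibition, with Rattus norvegicus as the target, read by paw edema, with stated times of 1 h and 2 h, at a dose of 100 mg/kg by the oral route; on this read-out lower numbers stand for less inhibition and higher numbers for more inhibition at the one dose given (going by the name of the read-out). Compound 2 `N#Cc1c(Nc2ccccc2)nc(SCC(=O)Nn2c(COc3ccc(Cl)cc3Cl)nc3ccccc3c2=O)nc1-c1ccccc1` gives 78.1%, the step of a number 11.4 percentage points higher from compound 1 to compound 2 (beyond the scatter) being the only one in the set beyond the scatter that went upward. Compound 3 `N#Cc1c(Nc2ccc(Cl)cc2)nc(SCC(=O)Nn2c(COc3ccc(Cl)cc3Cl)nc3ccccc3c2=O)nc1-c1ccccc1` gives 57.9% and stands lowest of the three: a number 8.8 percentage points lower from compound 1 to compound 3 (within the scatter), while a number 20.2 percentage points lower from compound 2 to compound 3 (beyond the scatter).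

Compound 4 `N#Cc1c(Nc2ccc(O)cc2)nc(SCC(=O)Nn2c(COc3ccc(Cl)cc3Cl)nc3ccccc3c2=O)nc1-c1ccccc1` differs from compound 3 by hydroxy in place of chloro on an aromatic carbon. Within the data shown here, no measured step swaps hydroxy for chloro, so only a number 20.2 percentage points lower from compound 2 to compound 3 (beyond the scatter) bears on it, showing that removing the chloro from this position lifted the read-out. Compound 4 is therefore expected to return part of the way toward compound 2, giving an estimated 68%, between 52% and 84%. The expected step is a number 10.1 percentage points higher from compound 3 to compound 4 (beyond the scatter), modest and upward.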

Compound 4, a percentage reported as inhibition, in the whole organism at one dose (the size of the read-out at that dose, not a potency): 59.7%
Beside the measured number, compound 4's estimate is 8.3 percentage points above it; measured number inside the range.
By their numbers in this assay, from the lowest: compounds 3, 4 and 1 (each within the scatter of the next); then compound 2.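

In this assay, hydroxy in place of chloro at this position changes little (a number 1.8 percentage points higher from compound 3 to compound 4 (within the scatter)), even though the new group brings a hydrogen-bond donor and acceptor that chloro lacks. Hydroxy, like chloro, falls short of the unsubstituted anilino compound (a number 18.4 percentage points lower from compound 2 to compound 4 (beyond the scatter)), so both groups tried para to the large group go with a lower number than hydrogen. The hydroxy compound also stays level with the chloro-bearing core (a number 7 percentage points lower from compound 1 to compound 4 (within the scatter)).

From the compounds shown here alone, whether a methoxy group or an amine at this place would also fall short of hydrogen remains open. Nothing available explains the drop from hydrogen.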